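Step from compound 2 to compound 3: methoxy to propargyloxy

The source may report more compounds than this note shows. Statements on the series, on what has been measured and on what is new or still open speak of the compounds shown alone.

Measured so far:
compound 1 `COc1ccc(/C=C/C(=O)Nc2cc(C(=O)c3cc(OC)c(OC)c(OC)c3)cc(OC)c2OC)cc1OC`: 2300 nM
compound 2 `COc1cccc(/C=C/C(=O)Nc2cc(C(=O)c3cc(OC)c(OC)c(OC)c3)cc(OC)c2OC)c1`: 8700 nM

In a functional assay on HT-29 cells (Homo sapiens) for cytotoxicity, read by MTT assay, with a stated time of 72 h (on this read-out lower numbers stand for stronger inhibition and higher numbers for weaker inhibition), compound 2 holds the highest of the two numbers, set apart from compound 1 by a 3.8-fold higher number from compound 1 to compound 2 (0.58 log units; beyond the scatter). Compound 3 `C#CCOc1cccc(/C=C/C(=O)Nc2cc(C(=O)c3cc(OC)c(OC)c(OC)c3)cc(OC)c2OC)c1` carries the change (ethynyl in place of hydrogen on a saturated chain carbon bound to an oxygen on an aromatic ring). Within the data shown here, the single measured step removed a methoxy rather than extending one, so it bears only loosely on this change; no step tests an ether enlarged in this way. A step within the scatter, in either direction, is expected. Compound 3 is estimated at 6000 nM (range 1500 nM to 25000 nM), a step of a 1.5-fold lower number from compound 2 to compound 3 (0.16 log units; within the scatter) expected.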

Compound 3, half-maximal inhibitory concentration: 8100 nM
For compound 3 the middle estimate is 1.4-fold (0.13 log units) below the measured one; low and high end bracket the measured number.
By their numbers in this assay, from the lowest: compound 1; then compounds 3 and 2 (each within the scatter of the next).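

In this assay, the move to 3-(propargyloxy)phenyl gives a 1.1-fold lower number from compound 2 to compound 3 (0.03 log units; within the scatter) and so leaves the number unchanged within the scatter, showing that this ether carbon accepts an ethynyl. The enlarged ether does not reach the level of the 3,4-dimethoxyphenyl compound, with a 3.5-fold higher number from compound 1 to compound 3 (0.55 log units; beyond the scatter) as the step beyond the scatter. No measurement at hand gives a cause for either step.

Open, going by these compounds, is whether a longer chain, an amine or a carboxylic acid on this ether would read differently. Also open, on these data alone, is whether the ethynyl would leave the number unchanged on compound 1.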